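Spiro-diamine to piperidine: kinetic solubility notes

A few compounds are considered here, and "the series" means these few. Any claim that something is new, unique, unknown or untested is made for them only; others in the source may bear on it.

compound 1 `CN1CC2(C1)CN(c1ccc(OCc3ccccc3)c(C(=O)Nc3ccnnc3)c1)C2` — 198000 nM
compound 2 `O=C(Nc1ccnnc1)c1cc(N2CCCC2)ccc1OCc1ccccc1` — 35000 nM
compound 3 `CN1CC2(CCN(c3ccc(OCc4ccccc4)c(C(=O)Nc4ccnnc4)c3)CC2)C1` — 266000 nM

In a physicochemical assay for solubility, measured as kinetic solubility (on this read-out higher numbers stand for higher solubility and lower numbers for lower solubility), compound 3 gives the highest number of the three, though its gap to compound 1 lies within the scatter; only compound 2 sits clearly lower. Compound 4 `O=C(Nc1ccnnc1)c1cc(N2CCCCC2)ccc1OCc1ccccc1` differs from compound 3 by a group of 6 heavy atoms (5 carbon, 1 nitrogen; one six-membered non-aromatic ring with 1 hetero atom) in place of a group of 10 heavy atoms (8 carbon, 2 nitrogen; one four-membered non-aromatic ring with 1 hetero atom, one six-membered non-aromatic ring with 1 hetero atom), on an aromatic carbon. For the measured compounds named here, two measured steps bear on this: a 7.6-fold higher number from compound 2 to compound 3 (0.88 log units; beyond the scatter) and a 5.7-fold lower number from compound 1 to compound 2 (0.75 log units; beyond the scatter). In both, exchanging the larger two-ring group for a single saturated ring goes with a modest fall, and compound 4 carries a single ring of that kind. A fall of similar size is therefore expected here: a 7.6-fold lower number from compound 3 to compound 4 (0.88 log units; beyond the scatter), downward. Compound 4 is estimated at 35000 nM, with a range of 12000 nM to 100000 nM.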

Compound 4, solubility: 60000 nM
Beside the measured number, compound 4's estimate is 1.7-fold (0.23 log units) below it, and the stated range covers the measured number.
By their numbers in this assay, from the lowest: compounds 2 and 4 (each within the scatter of the next); then compounds 1 and 3 (each within the scatter of the next).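

At this aromatic carbon, piperidin-1-yl and pyrrolidin-1-yl are not told apart in this assay, with a 1.7-fold higher number from compound 2 to compound 4 (0.23 log units; within the scatter) inside the scatter. Both two-ring groups stand clear of piperidin-1-yl, with a 4.4-fold lower number from compound 3 to compound 4 (0.65 log units; beyond the scatter) and a 3.3-fold lower number from compound 1 to compound 4 (0.52 log units; beyond the scatter), so the single-ring compounds now form one low pair against the two-ring pair. No supporting data bear on the cause of this gap.

From the compounds shown here alone, whether the gap goes with the extra ring or the extra nitrogen stays open. A piperazin-1-yl group on this carbon would bear on that question.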